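Methyl for Hydrogen on an Aromatic Hydroxy Group

The compounds below may be only part of what the source reports. "The series", "measured", "known", "first", "only" and "open" are said of these compounds alone.

Compound 1 `COc1cc(/C=C/C(=O)CC(=O)/C=C/c2ccc(OCC(=O)N[C@@H](CCCCN)C(=O)O)c(OC)c2)ccc1O` and compound 2 `COc1ccc(/C=C/C(=O)CC(=O)/C=C/c2ccc(OCC(=O)N[C@@H](CCCCN)C(=O)O)c(OC)c2)cc1OC` share the same core and differ in a single place. In a functional assay on the whole organism (Ear, strain ICR) for inhibition, with Mus musculus as the target, with stated times of 30 min and 2 h, at a dose of 1 umol/kg by the oral route (a higher number here means more inhibition at the dose given (going by the name of the read-out), a lower number less inhibition), compound 1 gives 41.1%. In this assay compound 2 gives 39.3%. The change between them is methyl in place of hydrogen on an oxygen on an aromatic ring, and the step it made is a number 1.8 percentage points lower from compound 1 to compound 2 (within the scatter).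

Compound 3 `COc1cc(/C=C/C(=O)CC(=O)/C=C/c2ccc(OCC(=O)N[C@@H](CCCCNC(=O)[C@H](CCCCN)NC(=O)[C@H](C)NC(=O)[C@H]3CCNC3)C(=O)O)c(OC)c2)ccc1O` carries a much longer chain on the amide than compound 1; the difference between the two cores is not broken down here. In this assay compound 3 gives 62%, which stands beyond the scatter above both compound 1 and compound 2 and is the highest of the three numbers.

Compound 4 `COc1ccc(/C=C/C(=O)CC(=O)/C=C/c2ccc(OCC(=O)N[C@@H](CCCCNC(=O)[C@H](CCCCN)NC(=O)[C@H](C)NC(=O)[C@H]3CCNC3)C(=O)O)c(OC)c2)cc1OC` is the counterpart of compound 3 that has not yet been measured. It differs from compound 3 by methyl in place of hydrogen on an oxygen on an aromatic ring. This is the same change as that from compound 1 to compound 2, made on the larger molecule, and the surroundings of the place read the same in both cases. The expected step is a number 2 percentage points lower from compound 3 to compound 4 (within the scatter), resting on the observation that the step of a number 1.8 percentage points lower from compound 1 to compound 2 (within the scatter) lay within the scatter. Compound 4 is therefore estimated at 60% in this assay, with an expected range from 48% to 71%.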

Compound 4, a percentage reported as inhibition, in the whole organism at one dose (the size of the read-out at that dose, not a potency): 57.7%
For compound 4 the middle estimate is 2.3 percentage points above the measured one; low and high end bracket the measured number.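

On the larger molecule, going from hydroxy to methoxy, that is, from 4-hydroxy-3-methoxyphenyl to 3,4-dimethoxyphenyl, gave in this assay a step of a number 4.3 percentage points lower from compound 3 to compound 4 (within the scatter). Set beside the same change on the smaller core, the two steps agree, so in this series the change carried from one core to the other without a step of different size: the same change on two cores in this assay, a number 1.8 percentage points lower (within the scatter) from compound 1 to compound 2 and a number 4.3 percentage points lower (within the scatter) from compound 3 to compound 4, 2.5 percentage points apart, within the scatter of two such steps This agreement rests on only two pairs of compounds and on a read-out taken at a single oral dose, which gives the size of the inhibition at that dose and not a potency, so it does not show that the change is without any effect, nor that it would carry over to a core other than these two.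

The compounds shown leave open whether an ethyl group or a longer chain on the same oxygen, or an amine or a fluorine in place of the hydroxy group, would leave the read-out as little moved as methyl does. They also leave open whether the two steps would still agree at other doses, since every number here comes from the one dose.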